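The compounds below may be only part of what the source reports. "The series", "measured", "known", "first", "only" and "open" are said of these compounds alone.

Within the data shown here, only two compounds have numbers so far. In a functional assay on HT-29 cells (Homo sapiens) for inhibition, read by sulforhodamine B assay, with a stated time of 48 h (on this read-out higher numbers stand for weaker inhibition of growth and lower numbers for stronger inhibition of growth), compound 1 (`CC1(/C=C/c2ccc(F)cc2)C=CC(=O)O1`) gives 34900 nM, the lower of the two numbers, while compound 2 (`COc1cc(/C=C/C2(C)C=CC(=O)O2)cc(OC)c1OC`) gives 390000 nM, a gap well beyond the usual scatter of repeat measurements. Compound 1 is therefore the stronger growth inhibitor of this pair.

Still unmeasured is compound 3 (`COc1ccc(/C=C/C2(C)C=CC(=O)O2)cc1`), which keeps the core of compound 1 and alters one group: methoxy in place of fluoro on an aromatic carbon, in counted terms (methoxy in place of fluoro on an aromatic carbon). Among the measured compounds shown here, no measured pair shows a single change of this kind, so there is no direct guide to the size of the step. For the measured compounds named here, the only hint is compound 2, the one measured compound carrying methoxy, at 390000 nM. A modest step towards a higher number in this assay, meaning weaker inhibition of growth, seems most likely, and it may not reach far past the scatter. The estimate amounts to an expected 2.4-fold higher number from compound 1 to compound 3 (0.39 log units; beyond the scatter). For compound 3 the expected value is 85000 nM, with an estimated range from 28000 nM to 260000 nM.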

Compound 3, concentration for total growth inhibition: 92900 nM
Estimate against measurement, compound 3: 1.1-fold (0.04 log units) below, within the range that was stated.
By their numbers in this assay, from the lowest: compound 1; then compound 3; then compound 2.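

Replacing fluoro with methoxy on an aromatic carbon, para to a group of 9 heavy atoms, can now be read directly. In this assay the swap gives a 2.7-fold higher number from compound 1 to compound 3 (0.43 log units; beyond the scatter) and so goes with weaker inhibition of growth, by a modest amount that still lies beyond the usual scatter. Among these compounds, compound 1 and compound 3 form the first pair that differs in one place only, so this step reflects that single swap with no other structural difference mixed in, though nothing measured here explains why the number rises.

Going by these compounds, what remains open is how other groups would behave in this same place, for example a chlorine atom, an amine, a carboxylic acid or a longer chain such as ethoxy, and whether any of them would give a lower number than fluoro does. On these data alone, it is also open whether methoxy in place of fluoro would give a step of similar size on another carbon of the aromatic ring, or on a core that differs from the core of compound 1.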